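Phenylpiperazine amide of a succinimide scaffold: expected dose

The source may hold more compounds than are shown below. What is called first, only, known or untested is meant among the compounds shown, and "the series" means these compounds.

Compound 1 `CC1(c2ccccc2)CC(=O)N(CC(=O)N2CCOCC2)C1=O`: 300 mg/kg
Compound 2 `CC1(c2ccccc2)CC(=O)N(CC(=O)N2CCN(c3ccccc3Cl)CC2)C1=O`: 100 mg/kg
Compound 3 `CC1(c2ccccc2)CC(=O)N(CC(=O)N2CCN(c3cccc(C(F)(F)F)c3)CC2)C1=O`: "not active" (no number reported)

In a functional assay on the whole organism (strain CD-1) with Mus musculus as the target, with a stated time of 2 h (on this read-out higher numbers stand for an effect only at larger amounts of compound and lower numbers for an effect already at smaller amounts), compound 1 gives 300 mg/kg. Compound 2, in this assay, gives 100 mg/kg. Within the data shown here, compound 3 stands apart from both: in this assay compound 3 was reported as "not active" (no number reported), so no single number describes where it stands, and no step from it to another compound can be sized. The two numbers that exist show that changing the amide partner within this series can move the minimum effective dose, and that one such partner gave no effect at all.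

Compound 4 `CC1(c2ccccc2)CC(=O)N(CC(=O)N2CCN(c3ccccc3)CC2)C1=O` is the unmeasured member of the group. It differs from compound 3 by hydrogen in place of trifluoromethyl on an aromatic carbon, so that the whole aryl piece on the piperazine becomes a plain phenyl. Among the measured compounds shown here, with no measured step between compounds that differ in this one place, there is no basis for sizing the step in this assay; the direction is open, since compound 3 gave no number and compound 2, which also carries an aryl on the piperazine, gave 100 mg/kg.

Compound 4 is therefore expected to give about 150 mg/kg in this assay, with the estimate lying between 50 mg/kg and 300 mg/kg.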

Compound 4, minimum effective dose: 300 mg/kg
For compound 4 the middle estimate is 2.0-fold (0.30 log units) below the measured one; the measured number falls inside the stated range.
By their numbers in this assay, from the lowest: compound 2; then compounds 1 and 4 (each within the scatter of the next).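

In this assay compound 4, with its plain phenyl, gives 300 mg/kg where compound 3 was reported as not active, so the piperazine aryl piece can carry an effect without trifluoromethyl, although the step between these two compounds cannot be read as a size. The plain phenyl also provides a reference for the chloro group, since hydrogen in place of chloro gives a 3.0-fold higher number from compound 2 to compound 4 (0.48 log units; beyond the scatter), a modest step beyond the usual scatter; against this same reference, chloro goes with a smaller effective dose and trifluoromethyl with no reported effect, so substitution on this aryl piece does not act in one direction across these compounds. Nothing available explains either difference.

The compounds shown leave open whether a smaller group such as fluoro or methyl, or a methoxy group, on this aromatic ring would follow chloro, hydrogen or trifluoromethyl in this assay. They also leave open whether the contrast belongs to the groups themselves or to where each sits, as chloro is not shown at the place that trifluoromethyl occupies in compound 3.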